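Working notes: cell toxicity readings in one compound series

The source may hold more compounds than are shown below. What is called first, only, known or untested is meant among the compounds shown, and "the series" means these compounds.

Measured so far:
- compound 1, `O=C(Nc1cccc(-n2cc(-c3ccncc3)c(-c3ccc(Cl)c(O)c3)n2)c1)Nc1cccc(C(F)(F)F)c1`, in a functional assay on MCF7 cells (Homo sapiens) for inhibition, read by sulforhodamine B assay, with a stated time of 48 h; on this read-out higher numbers stand for lower toxicity in this test and lower numbers for higher toxicity in this test: > 32500 nM, a limit of the assay.
- compound 2, `O=C(Nc1cccc(-n2cc(-c3ccncc3)c(-c3ccc(Cl)c(O)c3)n2)c1)Nc1ccc(Cl)c(Cl)c1`, in this assay: > 32500 nM, again a limit.
- compound 3, `COc1cc(-c2nn(-c3cccc(NC(=O)Nc4cccc(C(F)(F)F)c4)c3)cc2-c2ccncc2)ccc1Cl`, in this assay: > 50000 nM, also a limit.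

Compound 1 therefore stands only at a limit, and the same holds for the two further values. Two of the three readings sit at the limit of > 32500 nM in this assay, at which 2 of the 3 values shown sit, the third at the limit of > 50000 nM in this assay, at which 1 of the 3 values shown sits.

Compound 4, `O=C(Nc1cccc(-n2cc(-c3ccncc3)c(-c3ccc(Cl)c(O)c3)n2)c1)Nc1cc(C(F)(F)F)cc(C(F)(F)F)c1`, is not yet measured in this assay. It differs from compound 1 by trifluoromethyl in place of hydrogen on an aromatic carbon.

For the measured compounds named here, two measured steps touch the same region or the same molecule. The change of the aryl group on the amide-type nitrogen gives a step that the two limits leave unreadable from compound 1 to compound 2. The change on the oxygen of the aromatic ring gives a step that the two limits leave unreadable from compound 1 to compound 3. Neither step can be read in size, since every value in the series is a limit.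

Compound 4 is expected to stay at a limit as well, so the step that the limit leaves unreadable from compound 1 to compound 4 is expected to be none that can be read. The estimate for compound 4 in this assay is 45000 nM, with a range from 20000 nM to 110000 nM.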

Compound 4, concentration lethal to 50% of the cells: 31500 nM
Estimate against measurement, compound 4: 1.4-fold (0.15 log units) above, and the stated range covers the measured number.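

Trifluoromethyl in place of hydrogen on this aromatic carbon, meta to a trifluoromethyl group, brings the first actual number in the series in this assay: compound 4 gives 31500 nM. The change is an at least 1.0-fold lower number from compound 1 to compound 4 (0.01 log units; that floor lies within the scatter), so this pair gives only a floor for the step and does not establish a real shift in toxicity at this position. The earlier compounds could not show even this much, as all of them stand at limits of the assay and none of their steps can be read: the limit of > 32500 nM in this assay, at which 2 of the 4 values shown sit.

On these data alone, how far the reading moves with other groups at this position stays open, for example with an amine, a carboxylic acid or a longer chain in place of the added trifluoromethyl. As far as these compounds go, compound 3 gives > 50000 nM, a limit of the assay, so it also stays open whether the same trifluoromethyl would bring a readable number when methyl sits on the oxygen on the aromatic ring.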